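Swapping a Small Group for a Larger One on Two Cores

A few compounds are considered here, and "the series" means these few. Any claim that something is new, unique, unknown or untested is made for them only; others in the source may bear on it.

Compound 1 `NC(=S)N/N=C1/C=C(Nc2cccc(Cl)c2)C(Nc2cccc(Cl)c2)=NC1=O` and compound 2 `NC(=S)N/N=C1/C=C(Nc2ccc(F)cc2)C(Nc2ccc(F)cc2)=NC1=O` share a similar framework but differ in more than one place, so the difference between the two cores is not broken down here. In a functional assay on Bel-7402 cells (Homo sapiens) for antiproliferative activity, read by MTT assay, with a stated time of 72 h (on this read-out higher numbers stand for weaker inhibition and lower numbers for stronger inhibition), compound 1 gives 2190 nM, and compound 2 gives 3660 nM; these two numbers lie within the usual scatter of each other. Compound 3 `N/C(=N\N=C1\C=C(Nc2cccc(Cl)c2)C(Nc2cccc(Cl)c2)=NC1=O)SCc1ccccc1` arises from compound 1 by one change, (a group of 11 heavy atoms (8 carbon, 2 nitrogen, 1 sulfur; one six-membered aromatic ring of carbon only) in place of a group of 4 heavy atoms (1 carbon, 2 nitrogen, 1 sulfur; no ring), on a double-bonded nitrogen). This change brought a 3.3-fold higher number from compound 1 to compound 3 (0.51 log units; beyond the scatter), so that in this assay compound 3 gives 7160 nM. Compound 4 `N/C(=N\N=C1\C=C(Nc2ccc(F)cc2)C(Nc2ccc(F)cc2)=NC1=O)SCc1ccccc1` stands to compound 2 as compound 3 stands to compound 1: the change is a group of 11 heavy atoms (8 carbon, 2 nitrogen, 1 sulfur; one six-membered aromatic ring of carbon only) in place of a group of 4 heavy atoms (1 carbon, 2 nitrogen, 1 sulfur; no ring), on a double-bonded nitrogen, and the position it occupies on the core of compound 2 matches the position on the core of compound 1. Going by the values given here, only one example of this change has been measured, so any expectation for compound 4 rests on that single step. The number for compound 4 is expected to rise by a 3.3-fold higher number from compound 2 to compound 4 (0.52 log units; beyond the scatter) in this assay, because the same change gave a 3.3-fold higher number from compound 1 to compound 3 (0.51 log units; beyond the scatter). The estimate for compound 4 is 12000 nM, with a likely range from 5000 nM to 30000 nM.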

Compound 4, half-maximal inhibitory concentration: 7690 nM
Compound 4: the middle estimate sits 1.6-fold (0.19 log units) above what was measured, and the stated range covers the measured number.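

On the core of compound 2, in this assay, putting the larger group with its six-membered aromatic ring in place of the smaller group gives a 2.1-fold higher number from compound 2 to compound 4 (0.32 log units; beyond the scatter), so inhibition weakens here just as it did on the core of compound 1. The sizes of the two steps cannot be told apart, so the smaller size of the new step should not be read as a real difference between the cores: the same change on two cores in this assay, a 3.3-fold higher number (0.51 log units; beyond the scatter) from compound 1 to compound 3 and a 2.1-fold higher number (0.32 log units; beyond the scatter) from compound 2 to compound 4, 1.6-fold (0.19 log units) apart, within the scatter of two such steps

Going by these compounds alone, this supports carrying the change from one of these cores to the other, in direction and roughly in size, but it rests on only two pairs of compounds in one cell assay and does not show why the change weakens inhibition or that it would do so on any further core.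

Going by these compounds, it remains open how a methyl group, a longer chain or a carboxylic acid would behave in place of the larger group on the same double-bonded nitrogen. On these data alone, it is also open whether the step would hold on a core carrying a methoxy group instead of chlorine or fluorine.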